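A Heteroaryl Swap on the Amide-Linked Chain

The compounds below may be only part of what the source reports. "The series", "measured", "known", "first", "only" and "open" are said of these compounds alone.

Among the compounds with values here, compound 3 (`CC(C)(C)c1ccc(NC(=O)c2ncn(CC(=O)NCc3ccc4c(N)nccc4c3)n2)cc1`) is the only member of this small set that returned a number in an assay on isolated protein for inhibition of histone-lysine N-methyltransferase SETD7 (Homo sapiens), read by 33P incorporation; on this read-out higher numbers stand for weaker inhibition and lower numbers for stronger inhibition: compound 3 gives 79800 nM, a very weak result. Compound 1 (`Cc1ccc(NC(=O)c2ncn(CC(=O)NCCn3ccc4c(N)ncnc43)n2)cc1C`) was reported as "not active" (no number reported) in this assay, and compound 2 (`CC(C)(C)c1ccc(NC(=O)c2ncn(CC(=O)NCc3ccc4[nH]ncc4c3)n2)cc1`) was likewise reported as "not active" (no number reported), in both cases with no figure attached, so compound 3 stands alone as the sole measured point and cannot be ranked against the others.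

Compound 4 (`CC(C)(C)c1ccc(NC(=O)c2ncn(CC(=O)NCCn3ccc4c(N)ncnc43)n2)cc1`) differs from compound 3 at one place: a group of 11 heavy atoms (7 carbon, 4 nitrogen; one five-membered aromatic ring with 1 hetero atom, one six-membered aromatic ring with 2 hetero atoms) in place of a group of 11 heavy atoms (9 carbon, 2 nitrogen; one six-membered aromatic ring of carbon only, one six-membered aromatic ring with 1 hetero atom), on a saturated chain carbon bound to an amide-type nitrogen. The entering group, on a saturated chain carbon bound to an amide-type nitrogen, is the same group that compound 1 carries, and compound 1 was not active in this assay; compound 1 and compound 4 differ elsewhere, though, so that comparison is indirect. Within the data shown here, no step between measured compounds is available to calibrate this change. Since compound 3 already sits at the weak end of what this assay reports, and every other compound here returned no number, the expectation for compound 4 is that it is at best comparable to compound 3 and quite possibly beyond a numerical read-out. Compound 4 is expected to give about 120000 nM in this assay, within 40000 nM to 400000 nM. The step from compound 3 to compound 4 is thus estimated at a 1.5-fold higher number from compound 3 to compound 4 (0.18 log units; within the scatter), toward weaker inhibition, with a high chance that only a limit is reported.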

Compound 4, half-maximal inhibitory concentration: "not active" (no number reported)
Compound 4 has no reported number here, so the estimate cannot be set against anything.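

Within the data shown here, compound 4 gives no number in this assay and so no step from compound 3 to it can be read. No measured evidence bears on this result. The compounds shown leave open how the 1-aminoisoquinolin-6-yl group and the group that replaces it in compound 4 compare on a numerical scale.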